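Swapping Fluoro for Acetamido on Compound 1

The compounds below may be only part of what the source reports. "The series", "measured", "known", "first", "only" and "open" are said of these compounds alone.

In a functional assay on QGY-7703 cells (Homo sapiens) for cytotoxicity, read by MTT assay, with a stated time of 24 h (a higher number here means a weaker inhibitor, a lower number a stronger inhibitor), compound 1 `N#Cc1ccc(/C=C2\CN(S(=O)(=O)c3ccc(F)cc3)C/C(=C\c3ccc(C#N)cc3)C2=O)cc1` gives 11300 nM. Compound 3 `COc1cc(/C=C2\CN(S(=O)(=O)c3ccc(F)cc3)C/C(=C\c3cc(OC)cc(OC)c3)C2=O)cc(OC)c1` gives 11400 nM, within the scatter of compound 1, so the two stand level. Compound 2 `COc1cc(/C=C2\CN(S(=O)(=O)c3ccc(F)cc3)C/C(=C\c3cc(OC)c(OC)c(OC)c3)C2=O)cc(OC)c1OC` gives 2220 nM, a lower number than either of them and beyond the scatter. Compound 1 therefore sits in the upper pair of these three numbers, on the weaker side.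

Compound 4 `CC(=O)Nc1ccc(S(=O)(=O)N2C/C(=C\c3ccc(C#N)cc3)C(=O)/C(=C/c3ccc(C#N)cc3)C2)cc1` has not yet been measured. It differs from compound 1 by acetamido in place of fluoro on an aromatic carbon, para to a large group (acetamido in place of fluoro on an aromatic carbon). For the measured compounds named here, all three measured compounds carry the fluoro, so no measured step speaks directly to this change, and the data give no direction for it. No step beyond the scatter is therefore expected in this assay, and the estimated step is a 1.3-fold lower number from compound 1 to compound 4 (0.10 log units; within the scatter). Compound 4 is estimated at 9000 nM, with an expected range of 3500 nM to 22000 nM.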

Compound 4, half-maximal inhibitory concentration: 3320 nM
Compound 4: middle estimate off by 2.7-fold (0.43 log units), on the high side, outside the stated range (below it).
By their numbers in this assay, from the lowest: compounds 2 and 4 (each within the scatter of the next); then compounds 1 and 3 (each within the scatter of the next).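

In this assay, this aromatic carbon, para to a large group, turns out to matter: the change from 4-fluorophenyl to 4-acetamidophenyl gives a 3.4-fold lower number from compound 1 to compound 4 (0.53 log units; beyond the scatter), a step beyond the scatter and in the direction of a stronger inhibitor. The earlier compounds shown here all carried the fluoro and so could say nothing about this place, whereas this pair shows that the number can move with the rest of compound 1 held unchanged. Nothing available here explains why the step occurs.

From the compounds shown here alone, the finding rests on this single pair, so it remains open whether an amine, a carboxylic acid or a longer acyl chain at the same place would move the number in the same way. Also open, going by these compounds, is whether the same swap would give a similar step on compound 2 or compound 3, which differ from compound 1 in their other aromatic rings.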